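The source may report more compounds than this note shows. Statements on the series, on what has been measured and on what is new or still open speak of the compounds shown alone.

In an assay on isolated protein for inhibition of leukotriene B4 receptor 1 (Homo sapiens), tested at 10 uM (on this read-out higher numbers stand for more inhibition at the one concentration tested (going by the name of the read-out) and lower numbers for less inhibition), the three measured compounds read:

compound 1 `CCc1cc(C(C)=O)c(O)cc1OCCCCCCCC(C)(C)C#N` gives 66%
compound 2 `CCc1cc(C(C)=O)c(O)cc1OCCCCCC(C)(C)c1nnn(C)n1` gives 95%
compound 3 `CCc1cc(C(C)=O)c(O)cc1OCCCCCCC(=O)O` gives 87%

Compound 3 stands second highest of the three. Its nearest neighbour is compound 2, and the gap between them, a number 8 percentage points lower from compound 2 to compound 3 (within the scatter), lies within the scatter, so the two cannot be told apart. Compound 1 sits clearly lower, as the step of a number 21 percentage points higher from compound 1 to compound 3 (beyond the scatter) shows.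

Compound 4 `CCc1cc(C(C)=O)c(O)cc1OCCCCCCC(=O)Nc1nn[nH]n1` keeps the whole of compound 3 except one change at the chain end: (2H-tetrazol-5-yl)amino in place of hydroxy on a carbonyl carbon. Among the compounds with values here, no measured step replaces a hydroxy on a carbonyl carbon with an amino-linked ring, so none bears directly on this change. The closest guidance is indirect: a number 29 percentage points higher from compound 1 to compound 2 (beyond the scatter) shows that a tetrazole ring at the chain end sits well in this assay, and a number 21 percentage points higher from compound 1 to compound 3 (beyond the scatter) shows that a carboxy terminus does too. Both terminal groups carrying a ring or an acid lie near the top of the range, and the read-out cannot rise far above the value of compound 3. The expected step is therefore a number 1 percentage points higher from compound 3 to compound 4 (within the scatter), a change that is not expected to reach beyond the scatter.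

Compound 4 is estimated at 88% in this assay, within a range of 70% to 99%.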

Compound 4, a percentage reported as inhibition, at one concentration (the size of the read-out at that concentration, not a potency): 101%
Compound 4: middle estimate off by 13 percentage points, on the low side; the measured number lies above the stated range.
By their numbers in this assay, from the lowest: compound 1; then compounds 3, 2 and 4 (each within the scatter of the next, the first and the last beyond it).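

Replacing hydroxy with (2H-tetrazol-5-yl)amino on this carbonyl carbon gives a number 14 percentage points higher from compound 3 to compound 4 (beyond the scatter) in this assay, so a free carboxy at the chain end is not needed for strong inhibition at the one concentration tested. This much larger group is accepted at the position, and two quite differently built chain ends that both carry a tetrazole ring cannot be told apart, as the step of a number 6 percentage points higher from compound 2 to compound 4 (within the scatter) shows. The nitrile-ended chain stays clearly separate, with the step of a number 35 percentage points higher from compound 1 to compound 4 (beyond the scatter), and nothing in the data accounts for any of these differences.

With all of these numbers taken at a single concentration and the top three so close together, they give no potency ranking, and a full concentration series would be needed to separate those compounds. Going by these compounds, it also remains open whether the gain comes from the ring or from the amide link alone, which a plain primary amide or a methylamino group in place of the (2H-tetrazol-5-yl)amino group could help to settle, while a longer chain would test how far the ring can sit from the shared core.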